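The source may report more compounds than this note shows. Statements on the series, on what has been measured and on what is new or still open speak of the compounds shown alone.

In a functional assay on HCT-116 cells (Homo sapiens) for cytotoxicity (a lower number here means that less compound is needed, a higher number that more compound is needed for the effect), two compounds sharing one core have been measured so far. Compound 1 `CC(=O)SCC(=O)c1ccc(NS(=O)(=O)c2ccc(OC(F)(F)F)cc2)cc1` gives 8800 nM. Compound 2 `CC(=O)SCC(=O)c1ccc(NS(=O)(=O)c2ccc(Cl)cc2)cc1` gives 30800 nM, the higher of the two numbers, so more of it is needed for the effect. Going by the values given here, the only measured step is a 3.5-fold higher number from compound 1 to compound 2 (0.54 log units; beyond the scatter), with chloro in place of trifluoromethoxy on an aromatic carbon. It is modest but beyond the scatter.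

Compound 3 `COc1cccc(S(=O)(=O)Nc2ccc(C(=O)CSC(C)=O)cc2)c1` has not yet been measured. It carries 3-methoxyphenyl in place of 4-chlorophenyl on a sulfonyl sulfur. Among the compounds with values here, the measured step also concerns the group on that sulfur, so it is the only guide, but an indirect one, since no measured compound carries 3-methoxyphenyl. It suggests that changes here can shift the number modestly, though it does not fix a direction for this change. A slight move to a lower number is expected, but none beyond the scatter. The estimate means a 1.7-fold lower number from compound 2 to compound 3 (0.23 log units; within the scatter), an expected step smaller than the measured one. For compound 3 the expected value is 18000 nM, with an estimated range from 7000 nM to 45000 nM.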

Compound 3, half-maximal effective concentration: 2600 nM
The estimate for compound 3 lay 6.9-fold (0.84 log units) above the measured number; measured number below the stated range.
By their numbers in this assay, from the lowest: compound 3; then compound 1; then compound 2.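

In this assay, 3-methoxyphenyl in place of 4-chlorophenyl on the sulfonyl sulfur gives a 12-fold lower number from compound 2 to compound 3 (1.07 log units; beyond the scatter) and thus a large step, whereas the earlier change at this sulfur, a 3.5-fold higher number from compound 1 to compound 2 (0.54 log units; beyond the scatter) and a modest step, had shown only a smaller shift and gave no direction for this swap. The group on the sulfonyl sulfur can therefore move the number much further than the first pair showed, and among the three compounds the lowest number now belongs to compound 3, which has neither the chloro nor the trifluoromethoxy group of the other two. Nothing available here explains why this change produces a step of this size.

The swap replaces the chloro group with a methoxy group and also changes where the substituent stands, so the contribution of each remains unresolved; 4-methoxyphenyl and 3-chlorophenyl on the same sulfur would be needed to separate them. From the compounds shown here alone, it also remains open whether the lower number persists with a longer chain such as 3-ethoxyphenyl, or with an amine such as 3-aminophenyl, at this position.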